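Hydrogen in place of methyl on a cytotoxic compound

The source may report more compounds than this note shows. Statements on the series, on what has been measured and on what is new or still open speak of the compounds shown alone.

Within the data shown here, in a functional assay on PC-3 cells (Homo sapiens) for cytotoxicity, read by MTT assay, with a stated time of 72 h (on this read-out higher numbers stand for weaker inhibition and lower numbers for stronger inhibition), compound 1 (`Cc1ccc2[nH]c(-n3cccn3)c(C3=C(Br)C(=O)NC3=O)c2c1`) gives 26000 nM and holds the lower of the two numbers so far, while compound 2 (`Cc1ccc2[nH]c3c(c4c(c5ccnn53)C(=O)NC4=O)c2c1`) gives 75000 nM and lies beyond the scatter from it. Compound 3 (`O=C1NC(=O)C(c2c(-n3cccn3)[nH]c3ccccc23)=C1Br`) has not yet been measured and differs from compound 1 by hydrogen in place of methyl on an aromatic carbon in one place, hydrogen in place of methyl on an aromatic carbon. Among the measured compounds shown here, no measured pair shows this change, so in this assay no step beyond the scatter is expected, in either direction. The expected step (a 1.2-fold higher number from compound 1 to compound 3 (0.06 log units; within the scatter)) is only an estimate. Compound 3 is expected at 30000 nM (estimated range 12000 nM to 70000 nM).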

Compound 3, half-maximal inhibitory concentration: 27000 nM
For compound 3 the middle estimate is 1.1-fold (0.05 log units) above the measured one; low and high end bracket the measured number.
By their numbers in this assay, from the lowest: compounds 1 and 3 (each within the scatter of the next); then compound 2.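

Among these compounds, the pair of compound 1 and compound 3 gives the first measured reading of this position: in this assay it shows a 1.0-fold higher number from compound 1 to compound 3 (0.02 log units; within the scatter), so methyl and hydrogen on this aromatic carbon cannot be told apart on this read-out. Nothing measured here offers an explanation for this result.

As far as these compounds go, it remains open whether an amine, a carboxylic acid or a methoxy group on the same carbon would stand apart from methyl and hydrogen. From the compounds shown here alone, it also remains open whether the same change would behave alike on the core of compound 2.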